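The compounds below may be only part of what the source reports. "The series", "measured", "known", "first", "only" and "open" are said of these compounds alone.

Series notes. Compound 2 `CS(=O)(=O)N1CCC[C@H](NC(=O)[C@H](CCC2CCCCC2)NC(=O)c2ccc(CNC(=O)c3cnn(-c4ccccc4)c3N)cc2)C1` has been measured in an assay on HEK293T cells for inhibition of Discoidin domain-containing receptor 2 (Homo sapiens), read by NanoBRET, with a stated time of 2 h (on this read-out lower numbers stand for stronger inhibition and higher numbers for weaker inhibition), where compound 2 gives 3460 nM. Compound 1 `CCCNC(=O)[C@H](CCC1CCCCC1)NC(=O)c1ccc(CNC(=O)c2cnn(-c3ccccc3)c2N)cc1` gives 5250 nM in this assay; the step of a 1.5-fold lower number from compound 1 to compound 2 (0.18 log units; within the scatter) is within the scatter, so the two values cannot be told apart and compound 2 cannot be ranked against compound 1 on these numbers. Compound 3 `Nc1c(C(=O)NCc2ccc(C(=O)N[C@@H](CCC3CCCCC3)C(=O)NC3CCCN(C4COC4)C3)cc2)cnn1-c1ccccc1` is not yet measured. Compound 3 differs from compound 2 in one place: a group of 10 heavy atoms (8 carbon, 1 nitrogen, 1 oxygen; one four-membered non-aromatic ring with 1 hetero atom, one six-membered non-aromatic ring with 1 hetero atom) in place of a group of 10 heavy atoms (6 carbon, 1 nitrogen, 2 oxygen, 1 sulfur; one six-membered non-aromatic ring with 1 hetero atom), on an amide-type nitrogen. Going by the values given here, the only measured step that touches this amide nitrogen is a 1.5-fold lower number from compound 1 to compound 2 (0.18 log units; within the scatter), and it stayed within the scatter although the group exchanged there changed its atom count a good deal. Among the compounds with values here, no measured step exchanges one ring-bearing group for another at this nitrogen, so nothing in the data points to a shift in either direction. For compound 3 the expected step in this assay is therefore none beyond the scatter, a 1.0-fold higher number from compound 2 to compound 3 (0.00 log units; within the scatter). The estimate for compound 3 in this assay is 3500 nM, with a range from 1200 nM to 10000 nM.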

Compound 3, half-maximal inhibitory concentration: 3720 nM
Compound 3: middle estimate off by 1.1-fold (0.03 log units), on the low side; low and high end bracket the measured number.
By their numbers in this assay, from the lowest: compounds 2, 3 and 1 (each within the scatter of the next).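

In this assay, going by these compounds alone, exchanging the sulfur-bearing ring group for 1-(oxetan-3-yl)piperidin-3-yl on the amide-type nitrogen gives a 1.1-fold higher number from compound 2 to compound 3 (0.03 log units; within the scatter), the first step here between two ring-bearing groups; they have the same heavy-atom and acceptor counts but differ in their elements and ring count. Against propyl, the new group gives a 1.4-fold lower number from compound 1 to compound 3 (0.15 log units; within the scatter), so all three groups on this nitrogen remain within the scatter of one another and cannot be ranked. No available evidence bears on why these groups read alike.

As far as these compounds go, whether a primary amine, a carboxylic acid or a longer alkyl chain on this nitrogen would move the number beyond the scatter stays open. From the compounds shown here alone, what a change elsewhere in the shared core would do also stays open.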